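A Smaller Aromatic Ring on the Carbonyl of Compound 2

The source may report more compounds than this note shows. Statements on the series, on what has been measured and on what is new or still open speak of the compounds shown alone.

Compound 2 `COc1ccc(-c2cc3ccccc3nc2/C=C/C(=O)c2c(OC)cccc2OC)cc1` holds the lower of the two numbers recorded so far in a functional assay on A549 cells (Homo sapiens) for antiproliferative activity, read by XTT assay, with a stated time of 72 h (a higher number here means a weaker inhibitor, a lower number a stronger inhibitor), where compound 2 gives 7410 nM. Its nearest neighbour, compound 1 `COc1ccc(-c2cc3ccccc3nc2/C=C/C(=O)c2ccc(OC)cc2OC)cc1`, gives 7990 nM in this assay, and the step of a 1.1-fold lower number from compound 1 to compound 2 (0.03 log units; within the scatter) lies within the scatter, so the two cannot be told apart. Compound 3 `COc1ccc(-c2cc3ccccc3nc2/C=C/C(=O)c2ccco2)cc1` differs from compound 2 in one place: furan-2-yl in place of 2,6-dimethoxyphenyl on a carbonyl carbon. For the measured compounds named here, the only measured step bears just loosely on this change, since it exchanged one dimethoxyphenyl for another rather than the ring itself, and it was small (a 1.1-fold lower number from compound 1 to compound 2 (0.03 log units; within the scatter)). Going by the values given here, no measured pair shows what a furan-2-yl does on this carbonyl carbon. The expected step is a 1.2-fold higher number from compound 2 to compound 3 (0.08 log units; within the scatter), and it could fall either way. The estimate for compound 3 in this assay is 9000 nM, within a range from 3000 nM to 30000 nM.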

Compound 3, half-maximal inhibitory concentration: 6130 nM
The estimate for compound 3 lay 1.5-fold (0.17 log units) above the measured number; the range from low to high includes it.
By their numbers in this assay, from the lowest: compounds 3, 2 and 1 (each within the scatter of the next).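

At this carbonyl carbon the change is no longer only from one dimethoxyphenyl to another: furan-2-yl, a five-membered aromatic ring of 5 heavy atoms in place of a six-membered one, gives (a 1.2-fold lower number from compound 2 to compound 3 (0.08 log units; within the scatter)) and (a 1.3-fold lower number from compound 1 to compound 3 (0.12 log units; within the scatter)) in this assay. Both steps lie within the scatter, so across these three compounds neither dimethoxyphenyl ring is needed to reach a number of this size, and the three cannot be told apart. Nothing measured here accounts for this result.

The compounds shown leave open whether any group on this carbonyl carbon can move the number beyond the scatter. An amine, a carboxylic acid or a longer chain in place of the aromatic ring would test this.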